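Swapping Chloro for Methyl on a Shared Core

The source may report more compounds than this note shows. Statements on the series, on what has been measured and on what is new or still open speak of the compounds shown alone.

Of the compounds shown here, two sharing one core have been tested in a functional assay on the whole organism with Rattus norvegicus as the target; a higher number here means that more compound is needed for the effect, a lower number that less compound is needed. Compound 1 `Cc1ccccc1-c1n[nH]c(-c2ccccc2)n1` gives 2 mg/kg, while compound 2 `COc1cccc(-c2n[nH]c(-c3ccc(Cl)cc3C)n2)c1` gives 0.5 mg/kg, the lowest of the two numbers and separated from compound 1 by more than the usual scatter. Compound 3 `COc1cccc(-c2n[nH]c(-c3ccc(C)cc3C)n2)c1` differs from compound 2 by methyl in place of chloro on an aromatic carbon, a methyl in place of chloro on an aromatic carbon. For the measured compounds named here, no measured pair shows this exchange, so the expected step is modest, at most a slight rise within the scatter; the step expected is a 1.6-fold higher number from compound 2 to compound 3 (0.20 log units; within the scatter). Compound 3 is therefore estimated at 0.8 mg/kg, with a range from 0.3 mg/kg to 2.5 mg/kg.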

Compound 3, dose for half-maximal effect: 0.6 mg/kg
Compound 3: middle estimate off by 1.3-fold (0.12 log units), on the high side; low and high end bracket the measured number.
By their numbers in this assay, from the lowest: compounds 2 and 3 (each within the scatter of the next); then compound 1.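

In this assay, methyl in place of chloro on the aromatic carbon para to a large group gives a 1.2-fold higher number from compound 2 to compound 3 (0.08 log units; within the scatter). For the compounds shown here, this is the first comparison here that isolates one change, and at this position chloro and methyl cannot be told apart. Nothing available explains this result. From the compounds shown here alone, how an amine or a carboxylic acid would read at this position remains open. Compound 1 differs from compound 2 in more than one place, so which difference separates their numbers also remains unresolved.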